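A Small Chain Extension on an Inactive Thiadiazole Series

The source may hold more compounds than are shown below. What is called first, only, known or untested is meant among the compounds shown, and "the series" means these compounds.

Compound 1 `Cc1nnsc1CO/N=C/c1c(C)nn(C)c1Oc1ccccc1Cl` was tested in a functional assay on Huh-7 cells (Homo sapiens) for inhibition, read by MTT assay, with a stated time of 48 h; a higher number here means a weaker inhibitor, a lower number a stronger inhibitor. In this assay compound 1 gives > 50000 nM, which is a limit of the assay and not a number. Two neighbours differ from it in one place. Compound 2 `Cc1ccc(Oc2c(/C=N/OCc3snnc3C)c(C)nn2C)cc1` carries a 4-methylphenyl in place of the 2-chlorophenyl on an oxygen on an aromatic ring, and in this assay compound 2 gives > 50000 nM, again a limit. Compound 3 `Cc1nnsc1CO/N=C/c1c(C)nn(C)c1Oc1ccccc1OC(F)(F)F` carries a trifluoromethoxy in place of chloro on an aromatic carbon, and in this assay compound 3 gives > 50000 nM, also a limit. The steps a step that the two limits leave unreadable from compound 1 to compound 2 and a step that the two limits leave unreadable from compound 1 to compound 3 therefore cannot be read, because of the limit of > 50000 nM in this assay, at which 3 of the 3 values shown sit.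

Compound 4 `CCc1nnsc1CO/N=C/c1c(C)nn(C)c1Oc1ccccc1Cl` differs from compound 1 by methyl in place of hydrogen on a saturated chain carbon bound to an aromatic carbon. Within the data shown here, no measured step bears on this change, and the neighbours give no readable step of any size; they only show that changes elsewhere on the shared core left the value at the limit. The step that the limit leaves unreadable from compound 1 to compound 4 is thus expected to be none beyond the scatter. Compound 4 is accordingly expected to give an estimated 80000 nM, in a range from 20000 nM to 400000 nM, most likely reported again only as a limit.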

Compound 4, half-maximal inhibitory concentration: > 50000 nM
Compound 4: a limit, no number (the forecaster's own chance of this, stated with the estimate: 85%); the middle value does not contradict the limit.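

No new step can be read from compound 4, since its comparison with compound 1 joins two values that are each a limit of the assay and not a number: the limit of > 50000 nM in this assay, at which 4 of the 4 values shown sit.

The compounds shown leave open whether any change on the shared core shifts the response in this assay at all.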